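A few compounds are considered here, and "the series" means these few. Any claim that something is new, unique, unknown or untested is made for them only; others in the source may bear on it.

In a functional assay on HeLa cells (Homo sapiens) for antiproliferative activity, read by MTT assay, with a stated time of 48 h (on this read-out higher numbers stand for weaker inhibition and lower numbers for stronger inhibition), compound 3 `Oc1ccc2ccccc2c1C(Nc1nc2ccc(Cl)cc2s1)c1cn(-c2ccccc2)nc1-c1cccc(Cl)c1` gives 18300 nM and lies within the scatter of compound 2 `COc1cccc(-c2nn(-c3ccccc3)cc2C(Nc2nc3ccc(Cl)cc3s2)c2c(O)ccc3ccccc23)c1` at 30000 nM (the two cannot be ranked). Compound 1 `COc1ccc2nc(NC(c3cn(-c4ccccc4)nc3-c3ccc([N+](=O)[O-])cc3)c3c(O)ccc4ccccc34)sc2c1` stands clearly lower at 5540 nM and so inhibits more strongly than compound 3.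

Compound 4 `O=[N+]([O-])c1ccc(-c2nn(-c3ccccc3)cc2C(Nc2nc3ccc(Cl)cc3s2)c2c(O)ccc3ccccc23)cc1` has not been measured yet. It carries 4-nitrophenyl in place of 3-chlorophenyl on an aromatic carbon of a five-membered aromatic ring with 2 nitrogen (4-nitrophenyl in place of 3-chlorophenyl on an aromatic carbon).

Among the compounds with values here, the only measured single change is a 1.6-fold lower number from compound 2 to compound 3 (0.21 log units; within the scatter) (chloro in place of methoxy on an aromatic carbon). It stays within the scatter and does not involve 4-nitrophenyl, so it offers little guidance. The better clue is compound 1 at 5540 nM. Compound 1 carries the same 4-nitrophenyl, although it has methoxy where compound 4 has chloro on the shared core. A modest move toward stronger inhibition in this assay is therefore expected, estimated as a 2.0-fold lower number from compound 3 to compound 4 (0.31 log units; beyond the scatter) with much uncertainty. Compound 4 is estimated at 9000 nM (expected range 3000 nM to 27000 nM).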

Compound 4, half-maximal inhibitory concentration: 13400 nM
The estimate for compound 4 lay 1.5-fold (0.17 log units) below the measured number, within the range that was stated.
By their numbers in this assay, from the lowest: compound 1; then compounds 4, 3 and 2 (each within the scatter of the next, the first and the last beyond it).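

In this assay, 4-nitrophenyl in place of 3-chlorophenyl at this position gives a 1.4-fold lower number from compound 3 to compound 4 (0.14 log units; within the scatter), so these two groups cannot be ranked, while 4-nitrophenyl in place of 3-methoxyphenyl gives a 2.2-fold lower number from compound 2 to compound 4 (0.35 log units; beyond the scatter), a modest separation. With 4-nitrophenyl now present on both cores, chloro in place of methoxy on the shared core can also be read, and it gives a 2.4-fold higher number from compound 1 to compound 4 (0.38 log units; beyond the scatter). That swap does not carry over from one compound pair to the other, so its outcome changes with the group at this position: the same change on two cores in this assay, a 1.6-fold lower number (0.21 log units; within the scatter) from compound 2 to compound 3 and a 2.4-fold higher number (0.38 log units; beyond the scatter) from compound 1 to compound 4, 4.0-fold (0.60 log units) apart, beyond the scatter of two such steps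

Going by these compounds, whether a phenyl ring carrying an amine or a carboxylic acid at this position would fall in the same range remains open. Also open, on these data alone, is whether the mismatch between the two chloro-for-methoxy steps would hold with other groups, since it rests on a single pair of steps.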